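From 3-Nitrophenyl to 4-Acetylphenyl on the Amide

The source may hold more compounds than are shown below. What is called first, only, known or untested is meant among the compounds shown, and "the series" means these compounds.

Three measured compounds share one core and differ only in the aromatic ring on the amide-type nitrogen. In a functional assay on HCT-116 cells (Homo sapiens) for cytotoxicity, read by MTT assay (on this read-out higher numbers stand for weaker inhibition and lower numbers for stronger inhibition), compound 1 `CCn1cc(C(=O)Nc2ccccc2)c(=O)c2cc(F)c(N3CCNC(C)C3)c(F)c21`, whose ring carries no extra group, gives 12700 nM. With a hydroxy group on that ring, compound 2 `CCn1cc(C(=O)Nc2ccccc2O)c(=O)c2cc(F)c(N3CCNC(C)C3)c(F)c21` gives 5370 nM, and with a nitro group, compound 3 `CCn1cc(C(=O)Nc2cccc([N+](=O)[O-])c2)c(=O)c2cc(F)c(N3CCNC(C)C3)c(F)c21` gives 2710 nM. Compound 3 therefore stands clearly under compound 1, with a 4.7-fold lower number from compound 1 to compound 3 (0.67 log units; beyond the scatter), but it cannot be separated from compound 2, with a 2.0-fold lower number from compound 2 to compound 3 (0.30 log units; within the scatter).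

The next compound, compound 4 `CCn1cc(C(=O)Nc2ccc(C(C)=O)cc2)c(=O)c2cc(F)c(N3CCNC(C)C3)c(F)c21`, has 4-acetylphenyl in place of 3-nitrophenyl on an amide-type nitrogen. Going by the values given here, no measured step makes this exact exchange, so the evidence is indirect. Adding a group to the bare ring gave modest drops, a 2.4-fold lower number from compound 1 to compound 2 (0.37 log units; beyond the scatter) and a 4.7-fold lower number from compound 1 to compound 3 (0.67 log units; beyond the scatter). Exchanging one substituted ring for another, the closest parallel, gave only a 2.0-fold lower number from compound 2 to compound 3 (0.30 log units; within the scatter). A step within the scatter is therefore expected, with a slight lean upward, since compound 3 has the largest drop from compound 1. In this assay, the estimated step is a 1.5-fold higher number from compound 3 to compound 4 (0.17 log units; within the scatter). The expected value for compound 4 is 4000 nM, with an estimated range from 1500 nM to 11000 nM.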

Compound 4, half-maximal inhibitory concentration: 4600 nM
Estimate against measurement, compound 4: 1.2-fold (0.06 log units) below; the measured number falls inside the stated range.
By their numbers in this assay, from the lowest: compounds 3, 4 and 2 (each within the scatter of the next); then compound 1.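

In this assay, acetyl in place of hydrogen on the bare ring also gives a step beyond the scatter, a 2.8-fold lower number from compound 1 to compound 4 (0.44 log units; beyond the scatter), so all three substituted rings shown now stand under the unsubstituted phenyl ring of compound 1, and none goes against this. The substituted rings themselves do not separate: there is a 1.7-fold higher number from compound 3 to compound 4 (0.23 log units; within the scatter), and also a 1.2-fold lower number from compound 2 to compound 4 (0.07 log units; within the scatter), so 4-acetylphenyl cannot be told apart from either 3-nitrophenyl or 2-hydroxyphenyl on this amide-type nitrogen, even though the three rings carry different groups. Nothing measured here says why a group on this ring lowers the number, or why these different groups land so close together.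

Among the compounds shown, each group comes with its own place on the ring, so the effect of the group cannot be separated from the effect of where it sits. As far as these compounds go, whether an amine or a carboxylic acid on this ring would stay with these three compounds or move away from them also remains open.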